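The source may hold more compounds than are shown below. What is called first, only, known or untested is meant among the compounds shown, and "the series" means these compounds.

This piece concerns a small group of compounds that share one core and differ only in the group attached to a saturated chain carbon bound to an aromatic nitrogen. Compound 1 `COC(=O)c1ccc(NCc2cncn2Cc2ccccc2Cl)cc1-c1ccccc1` was tested in a toxicity assay on NIH3T3 cells (Mus musculus) for cytotoxicity, read by resazurin assay (on this read-out lower numbers stand for an effect already at smaller amounts and higher numbers for an effect only at larger amounts of compound), where compound 1 gives 10000 nM. Compound 2 `O=C(c1ccc(NCc2cncn2Cc2ccc(-c3ccccc3)cc2)cc1-c1ccccc1)N1CCCCC1` was run in the same test, and for compound 2 the result in this assay is reported only as a limit of the assay, > 1000 nM. That outcome matches (the limit of > 1000 nM in this assay, at which 1 of the 3 values shown sits).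

Compound 3 `COC(=O)c1ccc(NCc2cncn2Cc2ccccc2OC)cc1-c1ccccc1` was not run to a number: for compound 3 the entry in this assay reads "not determined" (no result reported), so compound 3 stands nowhere on the scale. Within the data shown here, the only full number in view is that of compound 1.

Compound 4 `COC(=O)c1ccc(NCc2cncn2Cc2cccc(Br)c2)cc1-c1ccccc1` has not yet been measured. Its structure differs from compound 3 in one place: 3-bromophenyl in place of 2-methoxyphenyl on a saturated chain carbon bound to an aromatic nitrogen. Among the measured compounds shown here, because no measured pair with a comparable change exists here, the size of the step from compound 3 to compound 4 in this assay cannot be read from the data; the expectation is a step that stays within the usual scatter, with no clear direction. Anchored on compound 1 with its 10000 nM, compound 4 is expected to give about 10000 nM, in a range from 3000 nM to 30000 nM.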

Compound 4, half-maximal effective concentration: > 10000 nM
Compound 4: a limit, no number; the forecaster's own chance of this, stated with the estimate: 40%; the middle value lies on the limit itself.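

For compound 4 the reading in this assay is a limit of the assay and not a number: (the limit of > 10000 nM in this assay, at which 1 of the 4 values shown sits). On a saturated chain carbon bound to an aromatic nitrogen, 3-bromophenyl in place of 2-chlorophenyl gives the only step that has a readable direction among these compounds (a number no lower from compound 1 to compound 4 (the limit leaves the size open)). This shows that, with this change at this place, the effect in this assay does not move to smaller amounts of compound, although the data give only that direction and no size.

How large the step from 2-chlorophenyl to 3-bromophenyl really is stays open, and no other step among these compounds can be read, as compound 3 has no result and compound 2 differs from the others in more than one place. Also open, from the compounds shown here alone, is how this assay would read with a phenyl group at this place that carries an amine or a carboxylic acid, or with a longer chain in place of the benzyl link.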